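Swapping the amide acyl group for a fluorophenyl ring

This account rests on a few compounds, and the source may have more. Where it says the series, first, only, none or still open, it means among the compounds named here.

compound 1 `CCCC(=O)Nc1ccc(N2CCN(c3ccc(OC[C@@H]4CO[C@@](Cn5cncn5)(c5ccc(Cl)cc5Cl)O4)cc3)CC2)cc1` gives 9930 nM
compound 2 `O=C(CCc1ccccc1)Nc1ccc(N2CCN(c3ccc(OC[C@@H]4CO[C@@](Cn5cncn5)(c5ccc(Cl)cc5Cl)O4)cc3)CC2)cc1` gives 5340 nM
compound 3 `O=C(Nc1ccc(N2CCN(c3ccc(OC[C@@H]4CO[C@@](Cn5cncn5)(c5ccc(Cl)cc5Cl)O4)cc3)CC2)cc1)C(/C=C/Cl)C/C=C/C(F)(F)F` gives 9570 nM

These three compounds share one core and differ only in the group attached to the amide carbonyl. All were tested in a functional assay on HepG2 cells (Homo sapiens) for inhibition, read by MTT assay, with a stated time of 48 h; on this read-out lower numbers stand for stronger inhibition and higher numbers for weaker inhibition. Compound 3 stands second highest of the three numbers: its value is practically the same as that of compound 1, as a 1.0-fold lower number from compound 1 to compound 3 (0.02 log units; within the scatter) shows, while the gap from compound 2 is a 1.8-fold higher number from compound 2 to compound 3 (0.25 log units; within the scatter); the gap from compound 1 to compound 2 is a 1.9-fold lower number from compound 1 to compound 2 (0.27 log units; within the scatter). Every one of these steps is within the scatter, so nothing in the measured set separates a short chain, a phenyl-bearing chain or a branched halogenated chain on this carbonyl.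

Compound 4 `O=C(Nc1ccc(N2CCN(c3ccc(OC[C@@H]4CO[C@@](Cn5cncn5)(c5ccc(Cl)cc5Cl)O4)cc3)CC2)cc1)c1cccc(F)c1` differs from compound 3 in the same place: 3-fluorophenyl in place of 1-(2-chloroethenyl)-5,5,5-trifluoropent-3-en-1-yl on a carbonyl carbon. The three measured steps are the ones that bear on this change, and given that a 1.0-fold lower number from compound 1 to compound 3 (0.02 log units; within the scatter) and a 1.8-fold higher number from compound 2 to compound 3 (0.25 log units; within the scatter) both stayed within the scatter, a step of no more than the scatter is expected here too, so the estimated change is a 1.3-fold lower number from compound 3 to compound 4 (0.11 log units; within the scatter). In this assay compound 4 is therefore expected to give about 7500 nM, with a likely range from 2500 nM to 22000 nM.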

Compound 4, half-maximal inhibitory concentration: 10800 nM
For compound 4 the middle estimate is 1.4-fold (0.16 log units) below the measured one, and the stated range covers the measured number.
By their numbers in this assay, from the lowest: compounds 2, 3, 1 and 4 (each within the scatter of the next, the first and the last beyond it).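

Putting an aromatic ring directly on the amide carbonyl, as the 3-fluorophenyl group of compound 4 does, gives a value in this assay that cannot be told apart from those of the open-chain groups of compounds 1 and 3, with steps of a 1.1-fold higher number from compound 1 to compound 4 (0.04 log units; within the scatter) and a 1.1-fold higher number from compound 3 to compound 4 (0.05 log units; within the scatter). Within the data shown here, the step from the phenethyl group is a 2.0-fold higher number from compound 2 to compound 4 (0.31 log units; beyond the scatter), which makes it the first step at this position to pass the scatter, although only modestly, so the acyl group is no longer entirely without a measurable effect on the number. Compounds 1 and 3 lie within the scatter of both compound 2 and compound 4, and no measurement available here gives a reason for this small gap.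

The compounds shown leave open whether the gap belongs to losing the chain of the phenethyl group or to the fluorine, a question that a plain phenyl ring on the carbonyl carbon would help to separate. They also leave open how the number would respond to an amine or a carboxylic acid at the end of a chain on this carbonyl.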